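Returning to a Carbamoyl on the Shared Core

The compounds below may be only part of what the source reports. "The series", "measured", "known", "first", "only" and "open" are said of these compounds alone.

Compound 1 `COc1ccc(NC(=O)c2cccc(Nc3ncc(F)c(Nc4ccc(F)cc4)n3)c2)cc1`: > 10000 nM
Compound 2 `O=C(Nc1cccc(Nc2ncc(F)c(Nc3ccc(F)cc3)n2)c1)c1ccncc1`: 4330 nM

Within the data shown here, in a functional assay on DU-145 cells (Homo sapiens) for antiproliferative activity, read by sulforhodamine B assay, with a stated time of 3 days (a higher number here means a weaker inhibitor of growth, a lower number a stronger inhibitor of growth), compound 2 holds the only number in this set. Compound 1 sits at a limit of the assay, (the limit of > 10000 nM in this assay, at which 1 of the 2 values shown sits). Compound 3 `O=C(Nc1nccs1)c1cccc(Nc2ncc(F)c(Nc3ccc(F)cc3)n2)c1` differs from compound 2 by (1,3-thiazol-2-yl)carbamoyl in place of ((pyridin-4-yl)carbonyl)amino on an aromatic carbon. Among the measured compounds shown here, the one measured step, an at least 2.3-fold lower number from compound 1 to compound 2 (0.36 log units; beyond the scatter), went the other way, from a carbamoyl to a ((pyridin-4-yl)carbonyl)amino, and compound 3 goes back to a carbamoyl, so a higher number is expected, a 1.8-fold higher number from compound 2 to compound 3 (0.27 log units; within the scatter). Compound 3 is estimated at 8000 nM, between 3000 nM and 20000 nM.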

Compound 3, concentration for 50% growth inhibition: > 10000 nM
Compound 3: a limit, no number; the forecaster's own chance of this, stated with the estimate: 40%; middle value at least 1.2-fold (0.09 log units) from the limit.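

For compound 3 the reading of > 10000 nM is a limit of this assay and not a number. Even so, (1,3-thiazol-2-yl)carbamoyl in place of ((pyridin-4-yl)carbonyl)amino on this aromatic carbon gives an at least 2.3-fold higher number from compound 2 to compound 3 (0.36 log units; beyond the scatter), so both carbamoyl compounds shown sit at the limit and only the ((pyridin-4-yl)carbonyl)amino compound gives a number. The step between compound 1 and compound 3 cannot be read, since both values are limits. Still open, going by these compounds, is whether the number of compound 2 follows the pyridin-4-yl ring or the direction of the amide, which a (pyridin-4-yl)carbamoyl or a benzoylamino group here would separate.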